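Isopropyl for trifluoromethyl on the phenol ring of compound 3

The source may hold more compounds than are shown below. What is called first, only, known or untested is meant among the compounds shown, and "the series" means these compounds.

Compounds 1 and 2 share one core, compound 3 and compound 4 another. Compound 1 `CSc1cc(C(=O)N2CCc3ccccc32)cc(C#N)c1O` carries a methylsulfanyl group on the phenol ring; in an assay on tissue (RPTEC cells) for inhibition of solute carrier family 22 member 12 (Homo sapiens), read by scintillation counting, with stated times of 15 min and 2 h (on this read-out higher numbers stand for weaker inhibition and lower numbers for stronger inhibition), compound 1 gives only a limit of the assay, > 100000 nM. Compound 2 `CC(C)(C)c1cc(C(=O)N2CCc3ccccc32)cc(C#N)c1O` carries tert-butyl in its place, and in this assay compound 2 gives 31600 nM. For the measured compounds named here, the step of an at least 3.1-fold lower number from compound 1 to compound 2 (0.50 log units; beyond the scatter) is the only measured step. Compound 3 `N#Cc1cc(C(=O)N2CS(=O)(=O)c3ccccc32)cc(C(F)(F)F)c1O` carries trifluoromethyl; in this assay compound 3 gives only a limit of the assay, > 100000 nM. Compound 3 therefore sits at the limit of > 100000 nM in this assay, at which 2 of the 3 values shown sit, and how it stands against compound 2 cannot be read from a limit.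

Compound 4 `CC(C)c1cc(C(=O)N2CS(=O)(=O)c3ccccc32)cc(C#N)c1O` differs from compound 3 by isopropyl in place of trifluoromethyl on an aromatic carbon, placed ortho to a hydroxy group and meta to a cyano group. This resembles the step from compound 1 to compound 2, where an alkyl group entering at this position gave an at least modest fall in the number, though on a different core and starting from a limit rather than a value. A drop of similar size, an at least 2.0-fold lower number from compound 3 to compound 4 (0.30 log units; that floor lies within the scatter), is therefore expected for compound 4, with wide uncertainty. For compound 4 in this assay a value near 50000 nM is expected, between 12000 nM and 200000 nM.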

Compound 4, half-maximal inhibitory concentration: 83300 nM
The estimate for compound 4 lay 1.7-fold (0.22 log units) below the measured number, within the range that was stated.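

Isopropyl in place of trifluoromethyl, ortho to a hydroxy group and meta to a cyano group, gives the core of compound 3 its first measured number: in this assay compound 4 gives 83300 nM. The step reads an at least 1.2-fold lower number from compound 3 to compound 4 (0.07 log units; that floor lies within the scatter), so on this core the change cannot be called a real fall, whereas the step on the core of compound 1 clears the scatter even at its floor. Compound 1 and compound 3 are limits of the assay, so both steps at this position start from no number, and each gives only a floor for its size: the limit of > 100000 nM in this assay, at which 2 of the 4 values shown sit.

Still open, as far as these compounds go, is how far the number moves at this position with other groups, such as a methoxy group, a carboxylic acid or an amine, and whether a longer chain would carry it further. Tert-butyl and isopropyl also stand on different cores, so the compounds shown cannot tell whether the choice between these two alkyl groups matters on a single core.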